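Methoxy in Place of Hydroxy: Predicting Compound 3

The source may report more compounds than this note shows. Statements on the series, on what has been measured and on what is new or still open speak of the compounds shown alone.

Measured compounds in a functional assay on NCI-H522 cells (Homo sapiens) for inhibition, read by sulforhodamine B assay, with a stated time of 48 h, tested at 0.01 uM; a lower number here means a stronger effect, a higher number a weaker effect of the compound at the concentration tested:
- compound 1 `O=C(Nc1cccc(-n2cc(-c3ccncc3)c(-c3cc(O)cc(Cl)c3)n2)c1)Nc1ccc(Cl)c(C(F)(F)F)c1` gives 56%
- compound 2 `O=C(Nc1cccc(-n2cc(-c3ccncc3)c(-c3cc(O)cc(Cl)c3)n2)c1)Nc1ccc(Cl)c(Cl)c1` gives 88%

Among these two numbers compound 1 stands lowest, which in this assay means the stronger effect; its only neighbour is compound 2, and the step of a number 32 percentage points higher from compound 1 to compound 2 (beyond the scatter) lies beyond the scatter, so the two compounds are clearly apart.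

Compound 3 `COc1cc(Cl)cc(-c2nn(-c3cccc(NC(=O)Nc4ccc(Cl)c(C(F)(F)F)c4)c3)cc2-c2ccncc2)c1` is built from compound 1 by a single change: methyl in place of hydrogen on an oxygen on an aromatic ring. Among the measured compounds shown here, the one measured step, a number 32 percentage points higher from compound 1 to compound 2 (beyond the scatter), concerns chloro in place of trifluoromethyl on an aromatic carbon, a different place in the molecule, so it says nothing direct about what a methyl on the phenol oxygen does here. For the measured compounds named here, no measured pair shows the hydroxy to methoxy change itself.

Going by the values given here, with no guiding step, compound 3 is expected to land near compound 1, the step of a number 9 percentage points higher from compound 1 to compound 3 (within the scatter) being estimated as none beyond the scatter, though the range must be wide. The estimate for compound 3 in this assay is therefore 65%, between 40% and 95%.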

Compound 3, a percentage reported as activity, at one concentration (the size of the read-out at that concentration, not a potency): 93%
Compound 3: the middle estimate sits 28 percentage points below what was measured; measured number inside the range.
By their numbers in this assay, from the lowest: compound 1; then compounds 2 and 3 (each within the scatter of the next).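

In this assay, methyl in place of hydrogen on the oxygen of the 3-chloro-5-hydroxyphenyl group is far from a neutral change (a number 37 percentage points higher from compound 1 to compound 3 (beyond the scatter)), so this position responds strongly to one added carbon. Of the two groups compared here on the otherwise unchanged molecule of compound 1, the free hydroxy goes with the stronger effect at the single concentration tested, and the methoxy with the much weaker one. This is one pair, so it describes this position on this molecule only, and nothing measured here gives a reason for the step.

On these data alone, what remains open is whether the loss follows from removing the hydrogen on that oxygen or from adding bulk there, a question that an amine in place of the hydroxy, or a longer chain such as ethoxy, could begin to address. As far as these compounds go, it also remains open whether hydroxy to methoxy has a similar effect when the chloro group of compound 2 replaces trifluoromethyl, and whether the difference between compound 1 and compound 3 would hold at other concentrations, since a reading at one concentration is not a potency.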